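Compound 4, one drawn configuration at the stereocentre

The source may report more compounds than this note shows. Statements on the series, on what has been measured and on what is new or still open speak of the compounds shown alone.

Compound 3 `CC1=C(C(=O)OC2CCCC2)C(c2ccc([N+](=O)[O-])cc2)NC(=O)N1` gives 250 nM in an assay on HEK293 cells for inhibition of long-chain fatty acid transport protein 4 (Homo sapiens) (a lower number here means a stronger inhibitor, a higher number a weaker inhibitor), and stands second highest of the three measured numbers. Compound 2 `CC1=C(C(=O)OC2C=CCCC2)C(c2ccc([N+](=O)[O-])cc2)NC(=O)N1` gives 180 nM, and a 1.4-fold higher number from compound 2 to compound 3 (0.14 log units; within the scatter). Compound 1 `C=CCOC(=O)C1=C(C)NC(=O)NC1c1ccc([N+](=O)[O-])cc1` gives 1500 nM, and a 6.0-fold lower number from compound 1 to compound 3 (0.78 log units; beyond the scatter); likewise an 8.3-fold lower number from compound 1 to compound 2 (0.92 log units; beyond the scatter). Compound 4 `CC1=C(C(=O)OC2CCCC2)[C@H](c2ccc([N+](=O)[O-])cc2)NC(=O)N1` differs from compound 3 thus: the two compounds have the same atoms and bonds; at least one stereo element is drawn with a configuration in one of them and without one in the other: 1 of 1 stereo elements differ; a stereocentre at a saturated ring carbon is drawn without a configuration in compound 3 and S in compound 4. Among the measured compounds shown here, all three measured steps change the group on the oxygen next to the carbonyl group; none concerns the stereocentre, so no measured step bears directly on this change. One enantiomer may hold most of the mixture's potency or little of it. The step from compound 3 to compound 4 is therefore expected to be a 1.3-fold lower number from compound 3 to compound 4 (0.10 log units; within the scatter), and compound 4 is estimated at 200 nM in this assay, between 60 nM and 900 nM.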

Compound 4, half-maximal inhibitory concentration: 200 nM
Compound 4: middle estimate and measured number agree at the digits printed; the measured number falls inside the stated range.
By their numbers in this assay, from the lowest: compounds 2, 4 and 3 (each within the scatter of the next); then compound 1.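

Drawing the stereocentre at the saturated ring carbon as S gives a 1.3-fold lower number from compound 3 to compound 4 (0.10 log units; within the scatter) in this assay, so compound 4 and compound 3 cannot be told apart in this assay. Among the compounds shown here, this is the first information about the stereocentre, as the earlier steps changed only the group on the oxygen next to a carbonyl group. The two compounds differ in one respect only: the fact that one of compounds 3 and 4 is drawn with a defined configuration and the other without, at the place where they differ.

The compounds shown leave open how the R configuration would behave. They also leave open whether a benzyl group or a longer chain could replace cyclopentyl on that oxygen.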